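The source may hold more compounds than are shown below. What is called first, only, known or untested is meant among the compounds shown, and "the series" means these compounds.

Compound 1 `Cc1cc(Cl)c(S(C)(=O)=O)cc1C(=O)N=C(N)N` is the starting point of this comparison. Within the data shown here, in a functional assay for inhibition of sodium/hydrogen exchanger (Oryctolagus cuniculus) (a lower number here means a stronger inhibitor, a higher number a weaker inhibitor), compound 1 gives 25 nM, the lowest of the three numbers measured so far, although the gap to compound 2 lies within the scatter. Compound 2 `Cc1cc(-c2ccc(Cl)cc2)c(S(C)(=O)=O)cc1C(=O)N=C(N)N` gives 45 nM in this assay, and compound 3 `Cc1cc(-c2cc(Cl)cc(Cl)c2)c(S(C)(=O)=O)cc1C(=O)N=C(N)N` gives 130 nM. Both of those compounds carry a ring on the carbon that holds the chloro group in compound 1, and each time the number rose: a 1.8-fold higher number from compound 1 to compound 2 (0.26 log units; within the scatter), whereas a 5.2-fold higher number from compound 1 to compound 3 (0.72 log units; beyond the scatter), and between the two ring-bearing compounds a 2.9-fold higher number from compound 2 to compound 3 (0.46 log units; beyond the scatter).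

Compound 4 `Cc1cc(Sc2ccc(Cl)cc2)c(S(C)(=O)=O)cc1C(=O)N=C(N)N` has not been measured yet. It differs from compound 1 in one place: (4-chlorophenyl)sulfanyl in place of chloro on an aromatic carbon. The relevant measured steps are the two that start from compound 1, both placing a larger group on the same carbon and both raising the number, one within the scatter and one beyond it. A similar small rise in this assay is therefore expected for compound 4, plausibly a 2.0-fold higher number from compound 1 to compound 4 (0.30 log units; within the scatter), expected because a 1.8-fold higher number from compound 1 to compound 2 (0.26 log units; within the scatter). For compound 4 the estimate in this assay is 50 nM, with a range from 20 nM to 130 nM.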

Compound 4, half-maximal inhibitory concentration: 19 nM
Compound 4: the middle estimate sits 2.6-fold (0.42 log units) above what was measured; measured number below the stated range.
By their numbers in this assay, from the lowest: compounds 4, 1 and 2 (each within the scatter of the next, the first and the last beyond it); then compound 3.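

In this assay, the much larger (4-chlorophenyl)sulfanyl group can take the place of chloro on this carbon without a measurable loss (a 1.3-fold lower number from compound 1 to compound 4 (0.12 log units; within the scatter)), so size alone does not set the number here. Attachment matters too: joining the 4-chlorophenyl ring through sulfur instead of directly gives a difference beyond the scatter (a 2.4-fold lower number from compound 2 to compound 4 (0.37 log units; beyond the scatter)), and the widest gap at this position separates the new group from 3,5-dichlorophenyl (a 6.8-fold lower number from compound 3 to compound 4 (0.84 log units; beyond the scatter)). Nothing available explains why the sulfur-linked group behaves differently from the directly attached ring.

From the compounds shown here alone, it remains open whether sulfur itself is what counts, which an oxygen, methylene or amine link to the same 4-chlorophenyl ring would test. Also open, going by these compounds, is whether a 3,5-dichlorophenyl ring held through sulfur would match compound 4.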